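A Pyridine Nitrogen Enters the Aryl Ether

A few compounds are considered here, and "the series" means these few. Any claim that something is new, unique, unknown or untested is made for them only; others in the source may bear on it.

Compound 2 `Cn1c(CN2C[C@@H]3C(COc4ccc(Cl)cc4)[C@@H]3C2)nc2ccccc21` was measured in an in vitro assay on HEK293 cells with metabotropic glutamate receptor 2 (Rattus norvegicus) as the target, read by FLIPR, in the presence of a further agent that is not named here (a higher number here means that more compound is needed for the effect, a lower number that less compound is needed), where compound 2 gives 26 nM. Its nearest neighbour, compound 1 `CC(C)c1ccc(OCC2[C@H]3CN(Cc4nc5ccccc5n4C)C[C@@H]23)cc1`, gives 26 nM, and the step of no change at the digits printed from compound 1 to compound 2 (within the scatter) lies within the scatter. Compound 3 `Cn1c(CN2C[C@@H]3C(COc4ccc(Cl)cn4)[C@@H]3C2)nc2ccccc21` differs from compound 2 by 5-chloropyridin-2-yl in place of 4-chlorophenyl on an oxygen on a saturated carbon. Within the data shown here, no measured step alters the aromatic ring itself; the single measured step, no change at the digits printed from compound 1 to compound 2 (within the scatter), only exchanged a group on that ring and left the value unchanged. The expected step of a 1.5-fold higher number from compound 2 to compound 3 (0.19 log units; within the scatter) is therefore small, with no clear direction beyond the scatter. Compound 3 is expected to give 40 nM, between 13 nM and 130 nM.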

Compound 3, half-maximal effective concentration: 26 nM
Estimate against measurement, compound 3: 1.5-fold (0.19 log units) above; the measured number falls inside the stated range.
By their numbers in this assay, from the lowest: compounds 1, 2 and 3 (each within the scatter of the next).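

Changing the aromatic ring itself, rather than only a group on it, gives no change at the digits printed from compound 2 to compound 3 (within the scatter) in this assay, so 5-chloropyridin-2-yl, with its hydrogen-bond acceptor, reads level with 4-chlorophenyl at this position. Exchanging 4-isopropylphenyl for 5-chloropyridin-2-yl gives no change at the digits printed from compound 1 to compound 3 (within the scatter), so two changes to this aryl group, made together, also leave the printed value where it was. No supporting data bear on this result.

Still open, on these data alone, is whether the pyridine holds this level with an amine or a nitrile in place of the chlorine. Also open, as far as these compounds go, is how a saturated ring such as piperidine would read in place of the aromatic ring.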